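This account rests on a few compounds, and the source may have more. Where it says the series, first, only, none or still open, it means among the compounds named here.

Compound 1 `COc1ccccc1Oc1ccc2c(NCCCNCc3ccco3)ccnc2c1`: 14500 nM
Compound 2 `COc1ccc(F)cc1CNCCCNc1ccnc2cc(Oc3ccccc3)ccc12`: 14500 nM

In a physicochemical assay for solubility, with a stated time of 18 h, at pH 7.4 (a lower number here means a less soluble compound, a higher number a more soluble compound), compound 1 gives 14500 nM. In this assay compound 2 gives 14500 nM, level with compound 1 at the digits shown, the two values lying within the scatter of each other. Compound 3 `COc1ccc(F)cc1CNCCCNc1ccnc2cc(Oc3ccccc3OC)ccc12` has not yet been measured. It differs from compound 2 in one place: methoxy in place of hydrogen on an aromatic carbon. Among the measured compounds shown here, no step between two measured compounds shows this change on its own, so its size is not known from the data. Compound 1 carries the same 2-methoxyphenoxy group while differing from compound 2 elsewhere, and the values of compound 1 and compound 2 do not differ beyond the scatter. On that basis the step is expected to be small, a 1.2-fold lower number from compound 2 to compound 3 (0.08 log units; within the scatter), a slight move toward lower solubility at most and probably within the scatter. Compound 3 is accordingly estimated at 12000 nM, with an expected range from 5000 nM to 30000 nM.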

Compound 3, solubility: 14500 nM
The estimate for compound 3 lay 1.2-fold (0.08 log units) below the measured number; the measured number falls inside the stated range.
By their numbers in this assay, from the lowest: compounds 1, 2 and 3 (each within the scatter of the next).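

In this assay, among the compounds shown here, methoxy in place of hydrogen on an aromatic carbon, ortho to a large group, gives no change at the digits printed from compound 2 to compound 3 (within the scatter), which is the first direct reading of this change at this position. With the 2-methoxyphenoxy group held in place, 5-fluoro-2-methoxyphenyl in place of furan-2-yl gives no change at the digits printed from compound 1 to compound 3 (within the scatter), so the change at the other end of the molecule can now also be read on its own. Nothing in the information available explains why either step reads as it does.

On these data alone, whether an amine or a carboxylic acid on the same aromatic carbon would give a step beyond the scatter remains open. The same question stands for a longer chain, or a morpholine, in place of the 5-fluoro-2-methoxyphenyl group.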